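Thiophene for phenyl in a cytotoxicity series

A few compounds are considered here, and "the series" means these few. Any claim that something is new, unique, unknown or untested is made for them only; others in the source may bear on it.

Compounds measured so far:
compound 1 `CCc1csc(CN[C@@H]2C[C@H]3C[C@@H]([C@H]2C)C3(C)C)c1`: 25000 nM
compound 2 `C[C@H]1[C@H](NCc2cc(-c3ccccc3)cs2)C[C@H]2C[C@@H]1C2(C)C`: 5000 nM

In an ADME assay on MDCK cells (Canis lupus familiaris) for cytotoxicity, read by microscopy, with a stated time of 48 h (on this read-out lower numbers stand for higher toxicity in this test and higher numbers for lower toxicity in this test), compound 2 gives the lowest of the two numbers, with compound 1 the nearest, as the step of a 5.0-fold lower number from compound 1 to compound 2 (0.70 log units; beyond the scatter) shows. Compound 3 `C[C@H]1[C@H](NCc2cc(-c3ccsc3)cs2)C[C@H]2C[C@@H]1C2(C)C` differs from compound 2 by thiophen-3-yl in place of phenyl on an aromatic carbon. For the measured compounds named here, only that one measured step is known, and it swaps an alkyl for an aryl rather than one aryl for another, so it bears only loosely here. Compound 3 is therefore expected to give about 5000 nM in this assay, between 2500 nM and 12500 nM. The step of no change at the digits printed from compound 2 to compound 3 (within the scatter) is expected to stay within the scatter.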

Compound 3, minimum cytotoxic concentration: 25000 nM
The estimate for compound 3 lay 5.0-fold (0.70 log units) below the measured number; the whole stated range lies below it.
By their numbers in this assay, from the lowest: compound 2; then compounds 1 and 3 (each within the scatter of the next).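

In this assay the step from phenyl to thiophen-3-yl is a 5.0-fold higher number from compound 2 to compound 3 (0.70 log units; beyond the scatter), so at this position one aromatic ring does not stand in for another. Thiophen-3-yl in place of ethyl gives no change at the digits printed from compound 1 to compound 3 (within the scatter), which leaves phenyl as the only one of the three groups set apart. Nothing available here explains the difference between the two aromatic rings.

As far as these compounds go, whether a pyridyl ring or a carboxylic acid at this position would fall with phenyl or with ethyl remains open. So does whether phenyl stands apart on any other core.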